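From 4-fluorophenyl to 1,3-thiazol-2-yl on a sulfonamide nitrogen

The compounds below may be only part of what the source reports. "The series", "measured", "known", "first", "only" and "open" are said of these compounds alone.

In a functional assay on RAW264.7 cells (Mus musculus) for inhibition (on this read-out higher numbers stand for weaker inhibition and lower numbers for stronger inhibition), compound 1 `CCOC(=O)C1=CCCCC1S(=O)(=O)Nc1ccc(F)cc1` gives 110 nM and stands level, within the scatter, with compound 2 `CCOC(=O)C1=CCCCC1S(=O)(=O)Nc1c(F)cccc1F` at 160 nM on the higher side of the numbers, while compound 3 `CCOC(=O)C1=CCCCC1S(=O)(=O)Nc1ccc(F)cc1F` gives 16 nM in this series. In compound 4 `CCOC(=O)C1=CCCCC1S(=O)(=O)Nc1nccs1` the change 1,3-thiazol-2-yl in place of 4-fluorophenyl on a sulfonamide nitrogen puts 1,3-thiazol-2-yl in place of 4-fluorophenyl on a sulfonamide nitrogen. Going by the values given here, the one measured single change, fluoro in place of hydrogen on an aromatic carbon, gave a 6.9-fold lower number from compound 1 to compound 3 (0.84 log units; beyond the scatter) and is a modest step beyond the scatter. Among the compounds with values here, no measured step covers replacing the whole ring, so this guide is loose. A higher number is expected in this assay with an estimated 2.3-fold higher number from compound 1 to compound 4 (0.36 log units; beyond the scatter) as an uncertain step. Compound 4 is estimated at 250 nM with an expected range from 50 nM to 1200 nM in this read-out.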

Compound 4, half-maximal inhibitory concentration: > 10000 nM
Compound 4: a limit, no number (the forecaster's own chance of this, stated with the estimate: 3%); at least 40-fold (1.60 log units) between middle value and limit.
By their numbers in this assay, from the lowest: compound 3; then compounds 1 and 2 (each within the scatter of the next). At a limit, above all of these: compound 4.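

The earlier compounds shown here all keep a fluorinated phenyl ring on the sulfonamide nitrogen, so they showed only what fluoro does on that ring. Replacing the whole ring with 1,3-thiazol-2-yl gives, in this assay, an at least 90-fold higher number from compound 1 to compound 4 (1.95 log units; beyond the scatter), a far larger step than any fluoro change. For compound 4 the result is a limit of the assay, not a number: the limit of > 10000 nM in this assay, at which 1 of the 4 values shown sits.

On these data alone, the full size of this step therefore stays open. A pyridin-2-yl ring on the same nitrogen would show whether a six-membered aromatic ring containing nitrogen holds up better than 1,3-thiazol-2-yl.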